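The source may report more compounds than this note shows. Statements on the series, on what has been measured and on what is new or still open speak of the compounds shown alone.

Measured so far:
- compound 1, `COc1cc(N2C(N)=C(C#N)C(c3cccc([N+](=O)[O-])c3)C3=C2CC(C)(C)CC3=O)cc(OC)c1OC`: in a functional assay on Ehrlich cells (Mus musculus) for cytotoxicity, tested at 10 ug/mL (a higher number here means a stronger effect of the compound at the concentration tested, a lower number a weaker effect), compound 1 gives 5%
- compound 2, `COc1cc(N2C(N)=C(C#N)C(c3ccc([N+](=O)[O-])cc3)C3=C2CC(C)(C)CC3=O)cc(OC)c1OC`: compound 2 gives 10%
- compound 3, `COc1cc(N2C(N)=C(C#N)C(c3c(OC)ccc4ccccc34)C3=C2CC(C)(C)CC3=O)cc(OC)c1OC`: compound 3 gives 0%

Compound 3 sits at the lower end of these three numbers, but the step of a number 5 percentage points lower from compound 1 to compound 3 (within the scatter) and the step of a number 10 percentage points lower from compound 2 to compound 3 (within the scatter) are each within the scatter, so the three compounds cannot be told apart on this evidence. The step of a number 5 percentage points higher from compound 1 to compound 2 (within the scatter) is likewise within the scatter.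

Compound 4, `COc1ccc(C2C(C#N)=C(N)N(c3cc(OC)c(OC)c(OC)c3)C3=C2C(=O)CC(C)(C)C3)cc1`, has not yet been measured. It differs from compound 3 in one place: 4-methoxyphenyl in place of 2-methoxynaphthalen-1-yl on a saturated ring carbon

The measured steps that bear on this change are those exchanging the group on the same saturated ring carbon, a number 5 percentage points lower from compound 1 to compound 3 (within the scatter) and a number 10 percentage points lower from compound 2 to compound 3 (within the scatter), neither of which left the scatter. Exchanging that group has so far produced no step beyond the scatter, so for compound 4 no step beyond the scatter is expected, a number 5 percentage points higher from compound 3 to compound 4 (within the scatter). Compound 4 is therefore estimated at 5%, with a range from 0% to 15%.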

Compound 4, a percentage reported as activity, at one concentration (the size of the read-out at that concentration, not a potency): 0%
The estimate for compound 4 lay 5 percentage points above the measured number, within the range that was stated.
By their numbers in this assay, from the lowest: compounds 3, 4, 1 and 2 (each within the scatter of the next).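

In this assay, 4-methoxyphenyl in place of 2-methoxynaphthalen-1-yl gave no change at the digits printed from compound 3 to compound 4 (within the scatter), so on this saturated ring carbon the loss of one six-membered aromatic ring of carbon only left no readable mark. Among these compounds, the exchange of nitro for methoxy on an aromatic carbon, seen here for the first time, gave a number 10 percentage points lower from compound 2 to compound 4 (within the scatter), and 4-methoxyphenyl in place of 3-nitrophenyl gave a number 5 percentage points lower from compound 1 to compound 4 (within the scatter), so neither the nitro group nor its placement is separated from methoxy by these numbers. Nothing available accounts for these results.

On these data alone, all four compounds remain within the scatter of one another, so it is still open whether any group on this carbon can move the read-out. As far as these compounds go, whether an aromatic ring carrying an amine or a carboxylic acid, or a longer chain in place of methoxy, would produce a step beyond the scatter also remains open.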